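A few compounds are considered here, and "the series" means these few. Any claim that something is new, unique, unknown or untested is made for them only; others in the source may bear on it.

Working notes on the series. Compound 1 `CCOC(=O)c1c(O)c2cccnc2n(-c2ccccc2)c1=O` carries the shared core with an ethoxy on the carbonyl carbon; in a functional assay on the whole organism for inhibition, with Rattus norvegicus as the target, read by paw edema, at a dose of 100 mg/kg by the oral route (on this read-out higher numbers stand for more inhibition at the one dose given (going by the name of the read-out) and lower numbers for less inhibition), compound 1 gives 23.5%. The two anilides measured so far are compound 2 `Cc1ccc(NC(=O)c2c(O)c3cccnc3n(-c3ccccc3)c2=O)cc1` and compound 3 `COc1ccc(NC(=O)c2c(O)c3cccnc3n(-c3ccccc3)c2=O)cc1`. In this assay compound 2 gives -3.5% and compound 3 gives 0.3%. Against compound 1 both steps are beyond the scatter: a number 27 percentage points lower from compound 1 to compound 2 (beyond the scatter) and a number 23.2 percentage points lower from compound 1 to compound 3 (beyond the scatter). Between the two anilides the step is a number 3.8 percentage points higher from compound 2 to compound 3 (within the scatter), within the scatter, so compound 3 stands together with compound 2 on the numbers shown and is set apart only from compound 1.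

Compound 4 `Nc1ccc(NC(=O)c2c(O)c3cccnc3n(-c3ccccc3)c2=O)cc1` differs from compound 3 in one place: amino in place of methoxy on an aromatic carbon. Within the data shown here, the one measured step that bears on this is the exchange of one group for another on the same aromatic carbon, a number 3.8 percentage points higher from compound 2 to compound 3 (within the scatter), which stayed within the scatter; the steps from compound 1 concern the group on the carbonyl carbon and do not bear on it. On that basis no step beyond the scatter is expected in this assay, and the estimated step is a number 0.7 percentage points higher from compound 3 to compound 4 (within the scatter). For compound 4 the expected value is 1%, with a range from -12% to 14%.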

Compound 4, a percentage reported as inhibition, in the whole organism at one dose (the size of the read-out at that dose, not a potency): -5.5%
The estimate for compound 4 lay 6.5 percentage points above the measured number; measured number inside the range.
By their numbers in this assay, from the lowest: compounds 4, 2 and 3 (each within the scatter of the next); then compound 1.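

In this assay, the aromatic carbon para to a large group has now carried methyl, methoxy and amino, and the new steps, a number 5.8 percentage points lower from compound 3 to compound 4 (within the scatter) and a number 2 percentage points lower from compound 2 to compound 4 (within the scatter), show that exchanges among these three groups separate no compound from another, even where amino brings a hydrogen-bond donor in place of methoxy, which has none. The third anilide also stands apart from the ester, a number 29 percentage points lower from compound 1 to compound 4 (beyond the scatter), so the gap to compound 1 holds with each of these three groups on the aromatic carbon. No measurement at hand offers an explanation for either result.

The compounds shown leave open whether a carboxylic acid, a chlorine or a longer alkyl chain on this aromatic carbon would give a number beyond the scatter from the three anilides. They also leave open whether a simple alkylamine in place of the substituted anilines on the carbonyl carbon would stay with the anilides or come closer to compound 1.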